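This account rests on a few compounds, and the source may have more. Where it says the series, first, only, none or still open, it means among the compounds named here.

Measured compounds:
compound 1 `CCNS(=O)(=O)CCNc1nonc1/C(=N/O)Nc1ccc(F)c(Br)c1` — in an assay on HeLa cells for inhibition of Indoleamine 2,3-dioxygenase 1 (Homo sapiens), read by spectrophotometry, with a stated time of 24 h (a lower number here means that less compound is needed, a higher number that more compound is needed for the effect), compound 1 gives 41 nM
compound 2 `NNS(=O)(=O)CCNc1nonc1/C(=N/O)Nc1ccc(F)c(Br)c1` — in this assay compound 2 gives > 800 nM

Compound 2 stands at the top of the numbers shown: its value in this assay is a limit of the assay and not a number, and compound 2 is the only one of the two compounds to sit there (the limit of > 800 nM in this assay, at which 1 of the 2 values shown sits). Among the compounds with values here, the measured step from compound 1 to compound 2 is the only comparison available, and it is large: an at least 19-fold higher number from compound 1 to compound 2 (1.29 log units; beyond the scatter).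

Compound 3 `CN(C)S(=O)(=O)CCCNc1nonc1/C(=N/O)Nc1ccc(F)c(Br)c1` has not been measured in this assay. Compared with compound 2, the change is (dimethylsulfamoyl)methyl in place of aminosulfamoyl on a saturated chain carbon, two bonds along the chain from a nitrogen on an aromatic ring.

The measured step bears on this change directly. Putting amino in place of ethyl on the sulfonamide nitrogen drove compound 2 to the limit; compound 3 takes the amino away again and carries (dimethylsulfamoyl)methyl instead, so a return toward the number of compound 1 is expected, with a step in this assay that is expected to be large, downward. Compound 3 is expected to give 80 nM, with a range from 25 nM to 300 nM, which means an expected step of an at least 10-fold lower number from compound 2 to compound 3 (1.00 log units; beyond the scatter).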

Compound 3, half-maximal effective concentration: 20 nM
Compound 3: middle estimate off by 4.0-fold (0.60 log units), on the high side, outside the stated range (below it).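

This position accepts (dimethylsulfamoyl)methyl in place of ethylsulfamoyl without any loss in this assay, with a 2.1-fold lower number from compound 1 to compound 3 (0.31 log units; beyond the scatter), a modest step. Set against aminosulfamoyl, the same group gives an at least 40-fold lower number from compound 2 to compound 3 (1.60 log units; beyond the scatter), so among these three compounds the high number goes with aminosulfamoyl and not with the sulfonamide as such, since the two compounds without that group both stay far lower. The value of compound 2 is a limit of the assay and not a number, so the true size of that large step stays open: the limit of > 800 nM in this assay, at which 1 of the 3 values shown sits.

Compound 3 differs from compound 1 both in the length of the chain and in the groups on the sulfonamide nitrogen, so the compounds shown cannot tell which of the two carries the modest step, and a 2-(dimethylsulfamoyl)ethyl group or a 3-(ethylsulfamoyl)propyl group would separate them. They also leave open how an amine, a carboxylic acid or a still longer chain would fare on this saturated chain carbon in place of the sulfonamide.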